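A few compounds are considered here, and "the series" means these few. Any claim that something is new, unique, unknown or untested is made for them only; others in the source may bear on it.

Measured so far: compound 1 `COc1cccc(S(=O)(=O)/C=C/c2ccccn2)c1` and compound 2 `COc1cccc(S(=O)(=O)/C=C/c2ccc(Cl)cn2)c1`. In an assay on U2OS cells for activation of nuclear factor erythroid 2-related factor 2 (Homo sapiens), read by chemiluminescence, with a stated time of 6 h (on this read-out higher numbers stand for an effect only at larger amounts of compound and lower numbers for an effect already at smaller amounts), compound 1 gives 2170 nM; in this assay compound 2 gives 132 nM.

Compound 1 stands highest of the two numbers; its nearest neighbour is compound 2, reached by a 16-fold lower number from compound 1 to compound 2 (1.22 log units; beyond the scatter), a large step that comes from chloro in place of hydrogen on an aromatic carbon.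

Compound 3 `COc1cccc(S(=O)(=O)/C=C/c2cccnc2)c1` is the next member: pyridin-3-yl in place of pyridin-2-yl on a double-bonded chain carbon bound to a double-bonded chain carbon. For the measured compounds named here, the only measured step, from compound 1 to compound 2, concerns an added chloro and says nothing about moving the ring nitrogen; no measured pair bears on this change. The expectation for compound 3 therefore rests on the value of compound 1 alone, with a wide range around it, and no step beyond the usual scatter is assumed in either direction. Compound 3 is estimated at 3000 nM (range 900 nM to 10000 nM). The expected step from compound 1 to compound 3 is a 1.4-fold higher number from compound 1 to compound 3 (0.14 log units; within the scatter).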

Compound 3, half-maximal effective concentration: 6290 nM
Beside the measured number, compound 3's estimate is 2.1-fold (0.32 log units) below it; the range from low to high includes it.
By their numbers in this assay, from the lowest: compound 2; then compound 1; then compound 3.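

In this assay, the swap of pyridin-2-yl for pyridin-3-yl on a double-bonded chain carbon bound to a double-bonded chain carbon gives a 2.9-fold higher number from compound 1 to compound 3 (0.46 log units; beyond the scatter), so the read-out responds at this place even though the atoms and the counts of the group stay the same. The earlier step, a 16-fold lower number from compound 1 to compound 2 (1.22 log units; beyond the scatter), came from adding chloro; the new one shows that the attachment of the aromatic ring alone also moves the number, with the pyridin-2-yl of compound 1 standing at the lower number of this pair. No measurement here bears on why the two ring attachments differ.

Whether chloro on the pyridin-3-yl ring would lower the number as it does on the pyridin-2-yl ring of compound 1 remains open, since the compounds shown contain no such pair. Also open, on these data alone, is how a pyridin-4-yl or a plain phenyl at the same chain carbon would compare, and whether an amine or a carboxylic acid in place of chloro would be tolerated on the ring.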